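Pyrrolidin-1-yl in Place of 3-Fluorocyclobutyl on a Carbonyl

The compounds below may be only part of what the source reports. "The series", "measured", "known", "first", "only" and "open" are said of these compounds alone.

Measured so far in an assay on HEK293 cells for positive allosteric modulation of metabotropic glutamate receptor 5 (Homo sapiens), read by FLIPR, with a stated time of 1 h; a higher number here means that more compound is needed for the effect, a lower number that less compound is needed:
- compound 1 `O=C1NCCc2nc(C#Cc3cccc(F)c3)sc21`, 290 nM
- compound 3 `O=C(C1CC(F)C1)N1CCc2nc(C#Cc3ccccc3)sc2C1`, 85 nM
- compound 2 `COc1ccccc1C#Cc1nc2c(s1)C(=O)NCC2` reaches only the limit of this assay, > 10000 nM.

Compound 3 stands at the lowest of the two numbers given; the nearest, compound 1, needs a higher concentration, and that gap is beyond the scatter. Compound 4 `O=C(N1CCCC1)N1CCc2nc(C#Cc3ccccc3)sc2C1` differs from compound 3 in one place: pyrrolidin-1-yl in place of 3-fluorocyclobutyl on a carbonyl carbon. Going by the values given here, no measured pair shows this same change, so the size of the step rests on judgement. A shift within the scatter, or a slightly higher number, is expected. Compound 4 is estimated at 150 nM, between 50 nM and 500 nM, which means an expected step of a 1.8-fold higher number from compound 3 to compound 4 (0.25 log units; within the scatter).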

Compound 4, half-maximal effective concentration: 9.8 nM
Beside the measured number, compound 4's estimate is 15-fold (1.18 log units) above it; measured number outside the range, below it.
By their numbers in this assay, from the lowest: compound 4; then compound 3; then compound 1. At a limit, above all of these: compound 2.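

In this assay, the group on this carbonyl carbon matters: pyrrolidin-1-yl in place of 3-fluorocyclobutyl gives an 8.7-fold lower number from compound 3 to compound 4 (0.94 log units; beyond the scatter) even though both groups count the same heavy atoms. Going by these compounds alone, the earlier compounds offered no pair differing in one place, so this is the first single change that can be read. Nothing measured here accounts for the step. Going by these compounds, the change alters ring size and ring atom together, so which of them matters remains open; cyclopentyl on the same carbonyl would separate them. On these data alone, whether piperidin-1-yl or dimethylamino there would hold the lower number also remains open.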